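The source may hold more compounds than are shown below. What is called first, only, known or untested is meant among the compounds shown, and "the series" means these compounds.

Measured so far in an ADME assay on Vero cells (Chlorocebus sabaeus) for cytotoxicity; on this read-out lower numbers stand for higher toxicity in this test and higher numbers for lower toxicity in this test:
Compound 1, `O=C(CN1CCCCC1)Nc1ccc(-c2nc3cc(C(F)(F)F)ccc3[nH]2)cc1`, gives 31000 nM.
Compound 2, `CC(=O)Nc1ccc(-c2nc3ccccc3[nH]2)cc1`, gives > 100000 nM, which is a limit of the assay and not a number.
Compound 3, `O=C(CCl)Nc1ccc(-c2nc3cc(C(F)(F)F)ccc3[nH]2)cc1`, gives 35000 nM.

Of the two results that are numbers, compound 3 has the highest, and compound 1 is the nearest to it; the step of a 1.1-fold higher number from compound 1 to compound 3 (0.05 log units; within the scatter) lies within the scatter of repeated measurements, so these two compounds cannot be told apart in this read-out. Compound 4, `CC(=O)Nc1ccc(-c2nc3cc(C(F)(F)F)ccc3[nH]2)cc1`, is the compound still to be measured. It differs from compound 3 in a single place: hydrogen in place of chloro on a saturated chain carbon bound to a carbonyl carbon. Going by the values given here, the only measured step that bears on this place is a 1.1-fold higher number from compound 1 to compound 3 (0.05 log units; within the scatter), in which a different group exchanged at the same saturated chain carbon left the number unchanged within the scatter. Compound 2 shares the acetamido group of compound 4 but differs elsewhere in its core, and because its result is the limit of > 100000 nM in this assay, at which 1 of the 3 values shown sits, it gives no number to lean on. The small change from chloro to hydrogen is therefore expected to move the value little in this assay, and the expected step is a 1.3-fold higher number from compound 3 to compound 4 (0.11 log units; within the scatter). Compound 4 is estimated at 45000 nM, within a range from 18000 nM to 110000 nM.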

Compound 4, half-maximal cytotoxic concentration: 50000 nM
Compound 4: the middle estimate sits 1.1-fold (0.05 log units) below what was measured, and the stated range covers the measured number.
By their numbers in this assay, from the lowest: compounds 1, 3 and 4 (each within the scatter of the next). At a limit, above all of these: compound 2.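

In this assay the saturated chain carbon bound to a carbonyl carbon now carries three different groups, and replacing chloro with hydrogen gives a 1.4-fold higher number from compound 3 to compound 4 (0.15 log units; within the scatter), while replacing piperidin-1-yl with hydrogen gives a 1.6-fold higher number from compound 1 to compound 4 (0.21 log units; within the scatter). Even with the whole piperidin-1-yl group gone and only hydrogen left, the number stays within the scatter, so compounds 1, 3 and 4 show no measurable dependence on the group at this carbon. The other change, trifluoromethyl in place of hydrogen on an aromatic carbon, gives an at least 2.0-fold lower number from compound 2 to compound 4 (0.30 log units; that floor lies within the scatter), which is only a floor, since the result of compound 2 is a limit and not a number: the limit of > 100000 nM in this assay, at which 1 of the 4 values shown sits.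

Going by these compounds, it remains open whether a different kind of group at this chain carbon, such as a carboxylic acid, a primary amine or a longer chain, would move the number beyond the scatter. On these data alone, it also remains open how large the trifluoromethyl step really is, since that floor gives no upper bound and a true size would need a number for compound 2.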